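Amide substituent change in a vitamin D3 receptor series

The compounds below may be only part of what the source reports. "The series", "measured", "known", "first", "only" and "open" are said of these compounds alone.

Two compounds of the series carry a number in an assay on HL-60 cells for agonist activity at vitamin D3 receptor (Homo sapiens), read by microscopy, with a stated time of 96 h; a lower number here means that less compound is needed, a higher number that more compound is needed for the effect. Compound 1 `CCN(CC)CCCNC(=O)c1ccc(C(CC)(CC)c2ccc(OCC(=O)C(C)(C)C)c(C)c2)n1CC` gives 22 nM in this assay. Compound 2 `CC[C@@H](C)[C@H](NC(=O)c1ccc(C(CC)(CC)c2ccc(OCC(O)C(C)(C)C)c(C)c2)n1CC)C(=O)OC`, which carries a different amide substituent and a hydroxyl in place of the ketone on the ether side chain, gives 26 nM in this assay; its number and that of compound 1 lie within the scatter of one another, so the two are not told apart by these measurements. Among the measured compounds shown here, no pair of measured compounds differs in a single place, so no step between measured compounds is available.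

Compound 3 `CCn1c(C(=O)Nc2ccc(OC(F)(F)F)cc2)ccc1C(CC)(CC)c1ccc(OCC(=O)C(C)(C)C)c(C)c1` has not yet been measured in this assay. Compared with compound 1 it shows one change: 4-(trifluoromethoxy)phenyl in place of 3-(diethylamino)propyl on an amide-type nitrogen. The shared core, the ether side chain with its ketone and the ethyl on the ring nitrogen are kept.

For the measured compounds named here, with no measured step of this kind to lean on, the direction of the change is open. Compound 3 is expected to give about 40 nM in this assay, within a range from 10 nM to 160 nM; the step of a 1.8-fold higher number from compound 1 to compound 3 (0.26 log units; within the scatter) is thus expected to be modest, possibly no more than the scatter.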

Compound 3, half-maximal effective concentration: > 50000 nM
Compound 3 gave a limit, no number (the forecaster's own chance of this, stated with the estimate: 5%); middle value at least 1200-fold (3.09 log units) from the limit.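

The amide nitrogen is a sensitive position in this series. With the shared core, the ether side chain with its ketone and the ethyl on the ring nitrogen kept, 4-(trifluoromethoxy)phenyl in place of 3-(diethylamino)propyl gives an at least 2200-fold higher number from compound 1 to compound 3 (3.35 log units; beyond the scatter) in this assay. Compound 1 and compound 2 differ in more than one place, so this position could not be read alone from them. The value of compound 3 is a limit of the assay and not a number, so the step has a lower bound only: the limit of > 50000 nM in this assay, at which 1 of the 3 values shown sits.

The step exchanges a whole substituent, so the compounds shown do not separate the loss of the diethylamino group or of the propyl chain from the entry of the aromatic ring or of its trifluoromethoxy group. A propyl chain without an amine and an unsubstituted phenyl on the same amide nitrogen, each on the core of compound 1, would divide these possibilities.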